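This account rests on a few compounds, and the source may have more. Where it says the series, first, only, none or still open, it means among the compounds named here.

Measured compounds:
compound 1, `CNC(=O)c1cn(Cc2ccc(-c3ccccc3)cc2)c2c(OC)c(N3CC[C@@H](CN)C3)c(F)cc2c1=O`: 82100 nM
compound 2, `COc1c(N2CC[C@@H](CN)C2)c(F)cc2c(=O)c(C(=O)O)cn(Cc3ccc(-c4ccc(F)cc4)cc3)c12`: 60900 nM

Of the compounds shown here, two have been measured so far in an assay on isolated protein for inhibition of DNA topoisomerase 1 (Homo sapiens), with a stated time of 15 min; a higher number here means a weaker inhibitor, a lower number a stronger inhibitor. Compound 1 `CNC(=O)c1cn(Cc2ccc(-c3ccccc3)cc2)c2c(OC)c(N3CC[C@@H](CN)C3)c(F)cc2c1=O` gives 82100 nM in this assay. Compound 2 `COc1c(N2CC[C@@H](CN)C2)c(F)cc2c(=O)c(C(=O)O)cn(Cc3ccc(-c4ccc(F)cc4)cc3)c12` gives 60900 nM in this assay, the lower of the two numbers, though the gap to compound 1 lies within the usual scatter of repeated measurements, so the two cannot be told apart on these data.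

Compound 3 `COc1c(N2CC[C@@H](CN)C2)c(F)cc2c(=O)c(C(=O)O)cn(Cc3ccc(-c4ccccc4)cc3)c12` has not yet been measured. It differs from compound 2 in one place: hydrogen in place of fluoro on an aromatic carbon. Going by the values given here, no step between two measured compounds matches this change, so there is nothing measured to lean on for its size. In this assay the expected step is small, in no preferred direction, and not beyond the scatter.

On that basis compound 3 is expected to give about 70000 nM in this assay, with a range from 30000 nM to 160000 nM. This estimate means an expected step of a 1.1-fold higher number from compound 2 to compound 3 (0.06 log units; within the scatter) in this assay.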

Compound 3, half-maximal inhibitory concentration: 26000 nM
Compound 3: middle estimate off by 2.7-fold (0.43 log units), on the high side; the measured number lies below the stated range.
By their numbers in this assay, from the lowest: compound 3; then compounds 2 and 1 (each within the scatter of the next).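

In this assay, replacing the fluoro of the 4-fluorophenyl group with hydrogen gives a 2.3-fold lower number from compound 2 to compound 3 (0.37 log units; beyond the scatter), so this aromatic carbon, para to a large group, does register in the read-out, and here the unsubstituted phenyl is the better of the two. With that phenyl in place on both sides, hydroxy in place of methylamino on the carbonyl carbon gives a 3.2-fold lower number from compound 1 to compound 3 (0.50 log units; beyond the scatter), so the two changes now each have a measured size, both modest, and compound 3 stands beyond the scatter from both earlier compounds, although all three numbers remain of a similar order. Nothing in the data shown explains why either change moves the number.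

The compounds shown leave open whether a chloro or a methoxy on that same aromatic carbon would read like the fluoro or like the hydrogen. They also leave open whether a primary amide or a methyl ester on the carbonyl carbon would fall with the methylamino or with the hydroxy, and whether the step on the phenyl would keep its size with a group other than the carboxylic acid there.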